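The source may hold more compounds than are shown below. What is called first, only, known or untested is meant among the compounds shown, and "the series" means these compounds.

Compound 1 `COc1cc2c(Oc3ccc(NC(=O)c4nn(-c5ccccc5C)c(=O)cc4C)cc3F)ccnc2cc1OCCCN1CCCCC1` gives 2500 nM in a functional assay on U-87MG ATCC cells (Homo sapiens) for inhibition, read by MTT assay, with a stated time of 72 h; on this read-out higher numbers stand for weaker inhibition and lower numbers for stronger inhibition. Compound 2 `COc1cc2c(Oc3ccc(NC(=O)c4nn(-c5ccccc5C)c(=O)cc4C)cc3F)ccnc2cc1OCCCN1CCC(C)CC1` differs from it by methyl in place of hydrogen on a saturated ring carbon and gives 2240 nM in this assay, the step being a 1.1-fold lower number from compound 1 to compound 2 (0.05 log units; within the scatter). Compound 3 `COc1cc2c(Oc3ccc(NC(=O)c4nn(-c5ccccc5OC(F)(F)F)c(=O)cc4C)cc3F)ccnc2cc1OCCCN1CCCCC1` carries a different core; the difference from compound 1 is trifluoromethoxy in place of methyl on an aromatic carbon. In this assay compound 3 gives 1300 nM, with a step of a 1.9-fold lower number from compound 1 to compound 3 (0.28 log units; within the scatter). Compound 4 `COc1cc2c(Oc3ccc(NC(=O)c4nn(-c5ccccc5OC(F)(F)F)c(=O)cc4C)cc3F)ccnc2cc1OCCCN1CCC(C)CC1` is not yet measured; it differs from compound 3 by methyl in place of hydrogen on a saturated ring carbon, the same change at the same place as that between compound 1 and compound 2. In this assay the expected step is a 1.1-fold lower number from compound 3 to compound 4 (0.03 log units; within the scatter), set beside the earlier step, since the same change gave a 1.1-fold lower number from compound 1 to compound 2 (0.05 log units; within the scatter) and nothing here suggests the new core should behave otherwise. Compound 4 is therefore expected to give 1200 nM, estimated between 600 nM and 2400 nM.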

Compound 4, half-maximal inhibitory concentration: 800 nM
Compound 4: middle estimate off by 1.5-fold (0.18 log units), on the high side; the measured number falls inside the stated range.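

In this assay the change to 4-methylpiperidin-1-yl gives a 1.6-fold lower number from compound 3 to compound 4 (0.21 log units; within the scatter), and it carries over from one core to the other without a detectable difference: the same change on two cores in this assay, a 1.1-fold lower number (0.05 log units; within the scatter) from compound 1 to compound 2 and a 1.6-fold lower number (0.21 log units; within the scatter) from compound 3 to compound 4, 1.5-fold (0.16 log units) apart, within the scatter of two such steps
The trifluoromethoxy change gives a 2.8-fold lower number from compound 2 to compound 4 (0.45 log units; beyond the scatter), the only step of the two beyond the scatter, and it too agrees with its earlier counterpart: the same change on two cores in this assay, a 1.9-fold lower number (0.28 log units; within the scatter) from compound 1 to compound 3 and a 2.8-fold lower number (0.45 log units; beyond the scatter) from compound 2 to compound 4, 1.5-fold (0.16 log units) apart, within the scatter of two such steps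
The two changes therefore combine across these four compounds with no sign of dependence on the partner group, but the methyl step alone stays within the scatter, and four compounds cannot show that this transfer holds more widely.

Still open, on these data alone, is whether the same steps hold with a dimethylamino group in place of piperidin-1-yl or a chlorine atom in place of trifluoromethoxy. A longer chain than the methyl on the saturated ring is equally untested here.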